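Trimming a single carbon from an inactive chain end

This account rests on a few compounds, and the source may have more. Where it says the series, first, only, none or still open, it means among the compounds named here.

Compound 1 `c1ccc2c(c1)CN[C@@H](CN(CCCCNC1CCNCC1)[C@H]1CCCc3cccnc31)C2` gives in a functional assay on cells for agonist activity at C-X-C chemokine receptor type 4 (Homo sapiens), read by fluorescence and calcium flux, with a stated time of 90 s (a higher number here means that more compound is needed for the effect, a lower number that less compound is needed), a reading of > 30000 nM, which is a limit of the assay and not a number.
Compound 2 `C(=C/CN(C[C@H]1Cc2ccccc2CN1)[C@H]1CCCc2cccnc21)\CNCC1CCOCC1` gives in this assay > 30000 nM, again a limit rather than a number.

Compound 2 therefore stands at the edge of what this assay can see: no concentration tested produced a half-maximal response. The step that the two limits leave unreadable from compound 1 to compound 2 links these two compounds, but with both of them at the limit its size cannot be read. Among the measured compounds shown here, the only evidence on the measured compounds is the limit of > 30000 nM in this assay, at which 2 of the 2 values shown sit.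

Compound 3 `C(=C/CN(C[C@H]1Cc2ccccc2CN1)[C@H]1CCCc2cccnc21)\CNC1CCOCC1` differs from compound 2 by oxan-4-yl in place of (oxan-4-yl)methyl on an amine nitrogen. For the measured compounds named here, no measured step bears readably on this change, so there is no basis for expecting movement in either direction beyond the scatter. With compound 2 at the limit, the step of a number no higher from compound 2 to compound 3 (the limit leaves the size open) is expected to leave compound 3 at or near that limit as well. Compound 3 is estimated at 30000 nM, within a range from 12000 nM to 100000 nM.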

Compound 3, half-maximal effective concentration: > 30000 nM
Compound 3: no number, only a limit; the forecaster's own chance of this, stated with the estimate: 85%; the middle value sits exactly at the limit.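

In this assay compound 3 gives > 30000 nM, a limit and not a number. Among the compounds shown here, compound 1, compound 2 and compound 3 all sit at this limit, so no step among them can be read. The compounds shown leave open whether oxan-4-yl in place of (oxan-4-yl)methyl on the amine nitrogen changes the response at all.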